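Swapping the Aryl Group on the Cyclopropane: Methoxy to Fluorine

This account rests on a few compounds, and the source may have more. Where it says the series, first, only, none or still open, it means among the compounds named here.

Compound 1, `CC[C@H](C)[C@H](N)CN(C(=O)[C@@H]1C[C@H]1c1ccc(Cl)cc1)c1ccc(-c2ccccc2)cc1`: 4300 nM.
Compound 2, `CC[C@H](C)[C@H](N)CN(C(=O)[C@@H]1C[C@H]1c1ccccc1Cl)c1ccc(-c2ccccc2)cc1`: a limit of the assay, > 25000 nM.
Compound 3, `CC[C@H](C)[C@H](N)CN(C(=O)[C@@H]1C[C@H]1c1cccc(OC)c1)c1ccc(-c2ccccc2)cc1`: 3000 nM.

In a functional assay for agonist activity at G protein-coupled receptor 88 (Homo sapiens), read by HTRF and cAMP accumulation (a lower number here means that less compound is needed, a higher number that more compound is needed for the effect), compound 3 and compound 1 sit close together, the difference a 1.4-fold lower number from compound 1 to compound 3 (0.16 log units; within the scatter) lying within the usual scatter. Compound 2 gives only a limit, shown as the limit of > 25000 nM in this assay, at which 1 of the 3 values shown sits, and so the step of an at least 5.8-fold higher number from compound 1 to compound 2 (0.76 log units; beyond the scatter) and the step of an at least 8.3-fold lower number from compound 2 to compound 3 (0.92 log units; beyond the scatter) can only be read as lower bounds.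

Compound 4, `CC[C@H](C)[C@H](N)CN(C(=O)[C@@H]1C[C@H]1c1ccc(F)cc1)c1ccc(-c2ccccc2)cc1`, has not yet been measured. It differs from compound 3 in one place: 4-fluorophenyl in place of 3-methoxyphenyl on a saturated ring carbon. For the measured compounds named here, two measured steps bear on this. The step of a 1.4-fold lower number from compound 1 to compound 3 (0.16 log units; within the scatter) shows that exchanging 4-chlorophenyl for 3-methoxyphenyl changed little. The step of an at least 5.8-fold higher number from compound 1 to compound 2 (0.76 log units; beyond the scatter) shows that moving the chlorine to the 2-chlorophenyl arrangement weakened the effect markedly. Compound 4 carries 4-fluorophenyl, which resembles the 4-chlorophenyl of compound 1 more than either alternative, so the expected step of a 1.3-fold higher number from compound 3 to compound 4 (0.12 log units; within the scatter) is small, within the scatter. Compound 4 is therefore estimated at 4000 nM in this assay, with a likely range from 1500 nM to 12000 nM.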

Compound 4, half-maximal effective concentration: 600 nM
Compound 4: the middle estimate sits 6.7-fold (0.82 log units) above what was measured; the whole stated range lies above it.
By their numbers in this assay, from the lowest: compound 4; then compounds 3 and 1 (each within the scatter of the next). At a limit, above all of these: compound 2.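

In this assay, fluoro in place of chloro on an aromatic carbon gives a 7.2-fold lower number from compound 1 to compound 4 (0.86 log units; beyond the scatter), so a single atom on the phenyl ring can move the number beyond the scatter even when its place on the ring stays the same. For the compounds shown here, until now, the only steps beyond the scatter at this cyclopropane carbon led to or from the poor result of compound 2, whereas 4-fluorophenyl in place of 3-methoxyphenyl gives a 5.0-fold lower number from compound 3 to compound 4 (0.70 log units; beyond the scatter), showing that an exchange between two aryl groups here can also reach a clearly lower number than either compound 1 or compound 3 gave. The step of an at least 41-fold lower number from compound 2 to compound 4 (1.61 log units; beyond the scatter) can be read only as a lower bound, as compound 2 stands at a limit of the assay: the limit of > 25000 nM in this assay, at which 1 of the 4 values shown sits.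

From the compounds shown here alone, it remains open whether a plain phenyl, a bromine or a trifluoromethyl group in place of that fluoro would lower the number further or raise it again, and whether fluoro suffers as chloro does in the 2-chlorophenyl arrangement of compound 2. Going by these compounds, the rest of the core is the same in all four compounds, so whether this fluoro for chloro step carries over to a different core also stays unknown.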